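The compounds below may be only part of what the source reports. "The series", "measured", "known", "first", "only" and "open" are said of these compounds alone.

Measured so far in an assay on CHO cells for displacement of a labelled ligand from adenosine receptor A1 (Homo sapiens), tested at 10 uM; on this read-out higher numbers stand for more inhibition at the one concentration tested (going by the name of the read-out) and lower numbers for less inhibition:
compound 1, `O=C(Nc1ccccc1Cl)Nc1nn(-c2ccccc2)c(=O)c2ccccc12`, gives 0%
compound 2, `COc1ccc(C(=O)Nc2nn(-c3ccccc3)c(=O)c3ccccc23)cc1`, gives 0%
compound 3, `COc1ccc(NC(=O)Nc2nn(-c3ccccc3)c(=O)c3ccccc23)cc1`, gives 4%

On the bare numbers compound 3 has the highest of the three, but the step of a number 4 percentage points higher from compound 1 to compound 3 (within the scatter) and the step of a number 4 percentage points higher from compound 2 to compound 3 (within the scatter) both lie within the scatter, so none of the three can be set apart from the others. The step of no change at the digits printed from compound 1 to compound 2 (within the scatter) likewise reads as no change. All three sit at the bottom of the read-out.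

Compound 4, `COc1ccc(NC(=O)Nc2nn(-c3ccccc3)c(=O)c3ccccc23)c(OC)c1`, differs from compound 3 by methoxy in place of hydrogen on an aromatic carbon. Among the compounds with values here, no measured step touches a substituent on the ring that already carries a methoxy group; the three known steps, no change at the digits printed from compound 1 to compound 2 (within the scatter), a number 4 percentage points higher from compound 1 to compound 3 (within the scatter) and a number 4 percentage points higher from compound 2 to compound 3 (within the scatter), alter the link between the carbonyl and that ring or exchange the ring as a whole, and all stayed within the scatter. Nothing in the series therefore points to a step beyond the scatter in this assay for this change, and the expected step of a number 1 percentage points lower from compound 3 to compound 4 (within the scatter) is none beyond the scatter. Compound 4 is estimated at 3%, with a range from 0% to 12%.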

Compound 4, a percentage reported as inhibition, at one concentration (the size of the read-out at that concentration, not a potency): 29%
Compound 4: middle estimate off by 26 percentage points, on the low side; the whole stated range lies below it.
By their numbers in this assay, from the lowest: compounds 1, 2 and 3 (each within the scatter of the next); then compound 4.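

In this assay, within the data shown here, methoxy in place of hydrogen on an aromatic carbon, ortho to a large group and meta to a methoxy group, gives a number 25 percentage points higher from compound 3 to compound 4 (beyond the scatter), the first single change to reach beyond the scatter. Putting 2,4-dimethoxyphenyl in place of 2-chlorophenyl on the amide-type nitrogen gives a number 29 percentage points higher from compound 1 to compound 4 (beyond the scatter), whereas 4-methoxyphenyl on that nitrogen stayed within the scatter, so this ring's substitution can move the read-out. The data offer no measured basis for explaining this step.

From the compounds shown here alone, whether the gain at this place depends on the methoxy group already on the ring remains open. Also open, going by these compounds, is whether an ethoxy group, a hydroxyl group or a dimethylamino group at the same place would give a step of similar size.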